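The source may hold more compounds than are shown below. What is called first, only, known or untested is meant among the compounds shown, and "the series" means these compounds.

Compound 2 `Cn1c(=O)c2c(nc(COc3cccc(Cl)c3)n2C)n(C)c1=O` gives 334 nM in an in vitro assay on cells for inhibition of Amine oxidase [flavin-containing] B (Homo sapiens), read by coupled enzyme assay, with a stated time of 20 min (on this read-out lower numbers stand for stronger inhibition and higher numbers for weaker inhibition), the lowest of the two numbers seen; compound 1 `Cc1cccc(OCc2nc3c(c(=O)n(C)c(=O)n3C)n2C)c1` gives 1230 nM. For the measured compounds named here, the one measured step, a 3.7-fold lower number from compound 1 to compound 2 (0.57 log units; beyond the scatter), came with chloro in place of methyl on an aromatic carbon. Compound 3 `Cn1c(=O)c2c(nc(COc3ccc(Br)cc3)n2C)n(C)c1=O` differs from compound 2 by 4-bromophenyl in place of 3-chlorophenyl on an oxygen on a saturated carbon. Going by the values given here, no measured step swaps one halogen for another, so the step from compound 1 to compound 2 bears only loosely on this change; a small shift in either direction, or none beyond the scatter, is expected. Compound 3 is therefore expected to give about 450 nM (range 150 nM to 1400 nM), which means a 1.3-fold higher number from compound 2 to compound 3 (0.13 log units; within the scatter).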

Compound 3, half-maximal inhibitory concentration: 189 nM
The estimate for compound 3 lay 2.4-fold (0.38 log units) above the measured number; measured number inside the range.
By their numbers in this assay, from the lowest: compounds 3 and 2 (each within the scatter of the next); then compound 1.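

In this assay the change of both halogen and ring position, a 1.8-fold lower number from compound 2 to compound 3 (0.25 log units; within the scatter), does not separate compound 3 from compound 2, so 4-bromophenyl on this oxygen reads the same as 3-chlorophenyl within the scatter. Against the methyl-bearing ring the picture is clearer: the step is a 6.5-fold lower number from compound 1 to compound 3 (0.81 log units; beyond the scatter), so both halogen-bearing compounds stand apart from compound 1. No measured evidence bears on the reason for this. Still open, going by these compounds, is whether 3-bromophenyl or 4-chlorophenyl would separate the halogen's identity from its ring position. Also open, on these data alone, is how an amine or a carboxylic acid on this phenyl ring would read.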